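Swapping nitro for bromo on a cytotoxic compound

The compounds below may be only part of what the source reports. "The series", "measured", "known", "first", "only" and "open" are said of these compounds alone.

The starting picture comes from three close relatives built on a shared core. In a functional assay on MCF7 cells (Homo sapiens) for cytotoxicity, read by MTT assay, with a stated time of 72 h (a lower number here means a stronger inhibitor, a higher number a weaker inhibitor), compound 1 (`CNC(=O)c1cc(Oc2ccc(C3=NNC(c4ccccc4)C3)cc2)ccn1`) gives 1240 nM as its result. The entry for compound 2 (`CNC(=O)c1cc(Oc2ccc(C3=NNC(c4cccc(Cl)c4Cl)C3)cc2)ccn1`) reads "not determined" (no result reported) and offers no guidance. Compound 3 (`CNC(=O)c1cc(Oc2ccc(C3CC(c4ccc([N+](=O)[O-])cc4)=NN3)cc2)ccn1`) gives 8030 nM and so holds the higher of the two actual numbers, which makes it the weaker inhibitor of that pair by a gap beyond the usual scatter of repeat measurements.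

Compound 4 (`CNC(=O)c1cc(Oc2ccc(C3CC(c4ccc(Br)cc4)=NN3)cc2)ccn1`) departs from compound 3 in one place (bromo in place of nitro on an aromatic carbon) with bromo in place of nitro on an aromatic carbon, para to a large group. Among the measured compounds shown here, no measured pair shows this swap directly, so any forecast is a judgment call. For the measured compounds named here, the only guide is that compound 1 gives 1240 nM and compound 3 gives 8030 nM in this assay, and so a result for compound 4 somewhere inside that gap seems reasonable. The expected change in this assay is a 2.7-fold lower number from compound 3 to compound 4 (0.43 log units; beyond the scatter) and points toward stronger inhibition, though with wide uncertainty. For compound 4 the estimated value is 3000 nM with an expected range from 900 nM to 9000 nM in all.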

Compound 4, half-maximal inhibitory concentration: 15300 nM
Estimate against measurement, compound 4: 5.1-fold (0.71 log units) below; measured number outside the range, above it.
By their numbers in this assay, from the lowest: compound 1; then compounds 3 and 4 (each within the scatter of the next).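

In this assay, putting bromo in place of nitro on an aromatic carbon, para to a large group, gives a 1.9-fold higher number from compound 3 to compound 4 (0.28 log units; within the scatter), so the two compounds cannot be told apart by this read-out. Among the compounds shown here, this is the first direct look at this position, and it shows that a single bromine atom can take the place of the larger nitro group, which carries hydrogen-bond acceptors where bromo has none, with no change that rises above the noise of the measurement. Nothing in the data shown gives a measured property that could account for this result.

The compounds shown leave open whether this position tolerates any group at all or only these two, since a single step cannot settle that, and an amine or a carboxylic acid on the same aromatic carbon would test it more sharply. They also leave open whether a methoxy group or a longer chain there could move the number beyond the scatter, in either direction.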